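Notes on the step from compound 2 to compound 4

A few compounds are considered here, and "the series" means these few. Any claim that something is new, unique, unknown or untested is made for them only; others in the source may bear on it.

Three compounds of the series have numbers in a functional assay on RS4-11 cells (Homo sapiens) for inhibition, read by CCK-8 assay, with a stated time of 48 h; on this read-out lower numbers stand for stronger inhibition and higher numbers for weaker inhibition. Compound 1 `COc1ccc(Oc2ccc([N+](=O)[O-])cc2-c2ccsc2S(=O)(=O)N2CCN(C(=O)Nc3ccc([N+](=O)[O-])cc3)CC2)cc1OC` is reported only as a limit, > 50000 nM, and (the limit of > 50000 nM in this assay, at which 1 of the 3 values shown sits). Compound 3 `COc1ccc(NC(=O)NCCNS(=O)(=O)c2ccc(-c3ccccc3OCc3cccc(O)c3)s2)cc1` gives 9400 nM. Compound 2 `Cc1ccc(-c2ccsc2S(=O)(=O)NCCNC(=S)Nc2ccc([N+](=O)[O-])cc2)c(Oc2ccc(O)c(O)c2)c1` gives 5100 nM, the lower of the two numbers available; the number for compound 3 lies within the usual scatter of it, so the two are not separated in this assay.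

Compound 4 `COc1ccc(NC(=O)NCCNS(=O)(=O)c2sccc2-c2ccc(C)cc2Oc2ccc(O)c(O)c2)cc1` has not been measured. It differs from compound 2 in one place: a group of 11 heavy atoms (8 carbon, 1 nitrogen, 2 oxygen; one six-membered aromatic ring of carbon only) in place of a group of 12 heavy atoms (7 carbon, 2 nitrogen, 2 oxygen, 1 sulfur; one six-membered aromatic ring of carbon only), on an amine nitrogen. Going by the values given here, no measured pair in the set shows a single change of this kind, so no step size is on record. Compound 3, which carries the same (4-methoxyphenyl)carbamoyl group on an amine nitrogen, gives 9400 nM, a number within the scatter of compound 2. The step from compound 2 to compound 4 is therefore expected to stay within the scatter, a 1.4-fold higher number from compound 2 to compound 4 (0.14 log units; within the scatter). Compound 4 is estimated at 7000 nM, with a range from 2500 nM to 20000 nM in this assay.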

Compound 4, half-maximal inhibitory concentration: 8200 nM
For compound 4 the middle estimate is 1.2-fold (0.07 log units) below the measured one; the measured number falls inside the stated range.
By their numbers in this assay, from the lowest: compounds 2, 4 and 3 (each within the scatter of the next). At a limit, above all of these: compound 1.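

In this assay, going by these compounds alone, (4-methoxyphenyl)carbamoyl in place of the group on the amine nitrogen of compound 2 gives a 1.6-fold higher number from compound 2 to compound 4 (0.21 log units; within the scatter), the first single-place step on record for the series. Within the data shown here, at this position, then, the group with sulfur and a second nitrogen can give way to (4-methoxyphenyl)carbamoyl with no step separable from the scatter in this assay, so the nitro-bearing and methoxy-bearing groups are not told apart here. Nothing on record bears on a cause for this step.

Still open, going by these compounds, is whether the amine nitrogen tolerates a group without a six-membered aromatic ring, such as a simple acetyl group or a carboxylic acid. Also open, on these data alone, is whether any group at this position gives a step beyond the scatter in either direction.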